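A 3-(4-methylpiperazin-1-yl)propyl Chain Added to Compound 1

A few compounds are considered here, and "the series" means these few. Any claim that something is new, unique, unknown or untested is made for them only; others in the source may bear on it.

For the measured compounds named here, compound 1 `Cn1cc(C2=C(c3n[nH]c4ncccc34)C(=O)NC2=O)c2ccccc21` gives 46100 nM in a functional assay on ECa-109 cells (Homo sapiens) for antiproliferative activity, read by MTT assay, with a stated time of 48 h (a lower number here means a stronger inhibitor, a higher number a weaker inhibitor), and is the only member of this small set with a number rather than a limit. Compound 2 `Cn1cc(C2=C(c3n[nH]c4ncccc34)C(=O)N(c3cccc4ccccc34)C2=O)c2ccccc21` carries naphthalen-1-yl in place of hydrogen on an amide-type nitrogen in a ring. In this assay compound 2 gives > 100000 nM, which is a limit of the assay and not a number. That change produced an at least 2.1-fold higher number from compound 1 to compound 2 (0.33 log units; beyond the scatter), resting on (the limit of > 100000 nM in this assay, at which 1 of the 2 values shown sits). Compound 3 `CN1CCN(CCCn2nc(C3=C(c4cn(C)c5ccccc45)C(=O)NC3=O)c3cccnc32)CC1` differs from compound 1 at a different place: 3-(4-methylpiperazin-1-yl)propyl in place of hydrogen on an aromatic nitrogen. Going by the values given here, the single measured step concerns the amide-type nitrogen and does not touch the aromatic nitrogen, and it offers little guidance for this change. No shown step argues for a move beyond the scatter in either direction. Compound 3 is therefore expected to give about 30000 nM, between 8000 nM and 120000 nM, which would mean an estimated step of a 1.5-fold lower number from compound 1 to compound 3 (0.19 log units; within the scatter).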

Compound 3, half-maximal inhibitory concentration: > 100000 nM
Compound 3: a limit, no number; the forecaster's own chance of this, stated with the estimate: 20%; middle value at least 3.3-fold (0.52 log units) away from the limit.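

With this result the aromatic nitrogen of the shared core, which the earlier step left untouched, has a measured step of its own: placing 3-(4-methylpiperazin-1-yl)propyl there in place of hydrogen gives an at least 2.1-fold higher number from compound 1 to compound 3 (0.33 log units; beyond the scatter) in this assay. The entry for compound 3, > 100000 nM, is a limit of the assay and not a number. The change on the aromatic nitrogen thus ends at the same limit as the change on the amide-type nitrogen, and compound 1 remains the only compound with a number, so the full size of neither step can be read: the limit of > 100000 nM in this assay, at which 2 of the 3 values shown sit.

The compounds shown leave open whether a simple methyl group on this aromatic nitrogen would keep a measurable value. They also leave open how a shorter chain ending in morpholine or a carboxylic acid would behave there.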